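The compounds below may be only part of what the source reports. "The series", "measured", "known", "first", "only" and "open" are said of these compounds alone.

Compound 1 `C(#Cc1ncnc2c1ncn2Cc1ccccc1)c1ccccc1` is assayed in a functional assay on K562 cells (Homo sapiens) for inhibition, read by thymidine incorporation, with a stated time of 48 h, tested at 10 ug/mL (on this read-out higher numbers stand for more inhibition at the one concentration tested (going by the name of the read-out) and lower numbers for less inhibition), where compound 1 gives 98%. Within the data shown here, compound 2 `C(#Cc1nc(-c2ccccc2)nc2c1ncn2Cc1ccccc1)c1ccccc1` gives 100% in this assay, and the two values sit within the scatter of each other, the only measured step being a number 2 percentage points higher from compound 1 to compound 2 (within the scatter) for phenyl in place of hydrogen on an aromatic carbon. Compound 3 `C=Cc1ncnc2c1ncn2Cc1ccccc1` differs from compound 1 by vinyl in place of 2-phenylethynyl on an aromatic carbon. Among the measured compounds shown here, no measured step touches this position, so nothing here bears on it directly. Compound 3 is expected to give 80% in this assay, within 40% to 100%, and the expected step is a number 18 percentage points lower from compound 1 to compound 3 (beyond the scatter).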

Compound 3, a percentage reported as inhibition, at one concentration (the size of the read-out at that concentration, not a potency): 100%
Compound 3: the middle estimate sits 20 percentage points below what was measured; the range from low to high includes it.
By their numbers in this assay, from the lowest: compounds 1, 2 and 3 (each within the scatter of the next).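

The position now has a measured step: vinyl in place of 2-phenylethynyl gives a number 2 percentage points higher from compound 1 to compound 3 (within the scatter) in this assay. On the core of compound 1, the six-membered aromatic ring of carbon only and the triple bond can therefore leave this position without a step beyond the scatter. Nothing available explains this result. On these data alone, whether an amine, a carboxylic acid or a longer chain at this position would give a similar reading remains open. Also open, as far as these compounds go, is whether compound 1 and compound 3 would still read alike at a lower concentration.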